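An All-Carbon Chain Replaces the Fluorinated One

This account rests on a few compounds, and the source may have more. Where it says the series, first, only, none or still open, it means among the compounds named here.

In a functional assay on HL-60 cells (Homo sapiens) for cytotoxicity, read by WST assay, with a stated time of 48 h (on this read-out higher numbers stand for weaker inhibition and lower numbers for stronger inhibition), compound 1 (`COc1cc(C(c2ccc(O)c(OC)c2)[C@H](C)[C@H](C)CO)ccc1O`) gives > 100000 nM, which is a limit of the assay. Within the data shown here, compound 2 (`COc1cc(C(c2ccc(O)c(OC)c2)[C@@H](C)[C@H](C)CF)ccc1O`) gives 32000 nM, the only actual number so far. Compound 3 (`COc1cc(C(c2ccc(O)c(OC)c2)[C@H](CC(C)C)C(C)C)ccc1O`) keeps the shared core and changes the chain: 1-isopropyl-3-methylbutyl in place of 2-(fluoromethyl)-1-methylpropyl on a saturated chain carbon bound to two aromatic carbons. Among the measured compounds shown here, the sole guide is one measured step, an at least 3.1-fold lower number from compound 1 to compound 2 (0.49 log units; beyond the scatter), and on that basis a further modest fall is expected. The estimated change is a 2.1-fold lower number from compound 2 to compound 3 (0.33 log units; beyond the scatter). Compound 3 is expected at 15000 nM, within a range of 4000 nM to 60000 nM.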

Compound 3, half-maximal inhibitory concentration: 9600 nM
The estimate for compound 3 lay 1.6-fold (0.19 log units) above the measured number, and the stated range covers the measured number.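

In this assay, the all-carbon 1-isopropyl-3-methylbutyl chain gives a 3.3-fold lower number from compound 2 to compound 3 (0.52 log units; beyond the scatter), so a fluorine is not required for activity at this position. Set against the hydroxymethyl chain, the same group gives an at least 10-fold lower number from compound 1 to compound 3 (1.01 log units; beyond the scatter). That step is only a bound because compound 1 stands at a limit: the limit of > 100000 nM in this assay, at which 1 of the 3 values shown sits.

The compounds shown do not separate the effect of the extra carbons from that of the branching. An unbranched hexyl chain or a chain ending in an amine would test what this position tolerates.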